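The compounds below may be only part of what the source reports. "The series", "measured", "known", "first", "only" and "open" are said of these compounds alone.

Measured so far in an ADME assay on Ava5 cells (Homo sapiens) for cytotoxicity; a higher number here means that more compound is tolerated, a lower number that less compound is tolerated:
compound 1 `NC(=S)Nc1cccc(OCCCCCCCc2ccccc2)c1` gives 23000 nM
compound 2 `NC(=S)Nc1cccc(OCCCCCOc2ccccc2)c1` gives > 50000 nM, a limit of the assay
compound 3 `CC(CCOc1ccccc1)CCOc1cccc(NC(N)=S)c1` gives > 50000 nM, also a limit of the assay

Compound 2 thus stands at a limit rather than a number, sharing that position with one other value, as the limit of > 50000 nM in this assay, at which 2 of the 3 values shown sit, shows. Compound 4 `COc1ccc(OCCCCCOc2cccc(NC(N)=S)c2)cc1` differs from compound 2 by methoxy in place of hydrogen on an aromatic carbon. Two measured steps exist here. The step of an at least 2.1-fold higher number from compound 1 to compound 2 (0.33 log units; beyond the scatter) reached the limit; the step that the two limits leave unreadable from compound 2 to compound 3 cannot be read, since its two values are both limits. Going by the values given here, neither concerns a methoxy on the ring, so no measured step bears directly on the change to compound 4. With compound 2 already at the limit, the step that the limit leaves unreadable from compound 2 to compound 4 is expected to be none beyond the scatter. Compound 4 is therefore estimated at 60000 nM, with a range from 25000 nM to 150000 nM, most likely reported as a limit again.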

Compound 4, half-maximal cytotoxic concentration: > 50000 nM
Compound 4 ended at the assay's limit; the forecaster's own chance of this, stated with the estimate: 70%; the middle value lies beyond the limit too.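

Compound 2 and compound 4 both stand at a limit of the assay, so no step between them can be read: the limit of > 50000 nM in this assay, at which 3 of the 4 values shown sit.

The compounds shown leave open whether methoxy in place of hydrogen changes how much compound is tolerated in this assay.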